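A few compounds are considered here, and "the series" means these few. Any claim that something is new, unique, unknown or untested is made for them only; others in the source may bear on it.

The measured compounds in this set:

Compound 1, `N=C(N)N/N=C(/C=C/c1ccc(Br)cc1)c1ccccc1`: 250 nM
Compound 2, `COc1ccc(/C=C/C(=N/NC(=N)N)c2ccccc2)cc1`: 14000 nM
Compound 3, `N=C(N)N/N=C(/C=C/c1ccccc1Br)c1ccccc1`: 4200 nM

All three were examined in a functional assay on MCF7 cells (Homo sapiens) for antiproliferative activity, read by MTT assay, with a stated time of 48 h; on this read-out lower numbers stand for stronger inhibition and higher numbers for weaker inhibition. In this assay compound 1 gives 250 nM, compound 2 gives 14000 nM, and compound 3 gives 4200 nM. Two single changes lead away from compound 1. The first, (methoxy in place of bromo on an aromatic carbon), brings a 56-fold higher number from compound 1 to compound 2 (1.75 log units; beyond the scatter). The second, by which the two cores differ, (2-bromophenyl in place of 4-bromophenyl on a double-bonded chain carbon bound to a double-bonded chain carbon), brings a 17-fold higher number from compound 1 to compound 3 (1.23 log units; beyond the scatter). Compound 3 thus stands between the other two, with compound 2 its nearer neighbour.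

Compound 4, `COc1ccccc1/C=C/C(=N/NC(=N)N)c1ccccc1`, has not yet been measured in this assay. Its relation to compound 3 is methoxy in place of bromo on an aromatic carbon. Going by the values given here, this is the same kind of change as the one from compound 1 to compound 2, not the same change: in the earlier pair the group sat para to a large group, whereas here it sits ortho to a large group. Because a 56-fold higher number from compound 1 to compound 2 (1.75 log units; beyond the scatter) was seen for the earlier pair, a weakening of similar direction is expected here too, though its size is less certain given the changed surroundings and the already weak starting point of compound 3. For compound 4 the expected step is a 9.5-fold higher number from compound 3 to compound 4 (0.98 log units; beyond the scatter). Compound 4 is therefore estimated at 40000 nM, within a range from 10000 nM to 160000 nM.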

Compound 4, half-maximal inhibitory concentration: 7200 nM
Beside the measured number, compound 4's estimate is 5.6-fold (0.74 log units) above it; measured number outside the range, below it.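

In this assay, going by these compounds alone, methoxy in place of bromo ortho to a large group gives a 1.7-fold higher number from compound 3 to compound 4 (0.23 log units; within the scatter), so on this core the exchange leaves no step that can be told apart from repeated measurement. The same exchange therefore cannot be carried at a fixed size from the core of compound 1 to the core of compound 3, and the two steps are clearly different: the same change on two cores in this assay, a 56-fold higher number (1.75 log units; beyond the scatter) from compound 1 to compound 2 and a 1.7-fold higher number (0.23 log units; within the scatter) from compound 3 to compound 4, 33-fold (1.51 log units) apart, beyond the scatter of two such steps. Within the data shown here, this shows that the large step seen on the first core does not hold on the second, but it rests on only two pairs and does not show why the steps differ, nor does it offer a rule for predicting the step on a further core.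

The compounds shown leave open whether a chloro, a hydroxyl or an amine at the same place would stay close to compound 3 and compound 4 or would open a step like the one on the core of compound 1. They also leave open whether the gap between the two steps would remain if the unsubstituted phenyl ring shared by all four compounds carried a fluoro or a methyl.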